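Swapping the sulfur-linked ring once more on a shared core

The source may hold more compounds than are shown below. What is called first, only, known or untested is meant among the compounds shown, and "the series" means these compounds.

Three measured compounds share one core and differ only in the ring attached to a sulfur. In a functional assay on MCF7 cells (Homo sapiens) for cytotoxicity, read by MTT assay, with a stated time of 24 h, tested at 16 ug/mL (a higher number here means a stronger effect of the compound at the concentration tested, a lower number a weaker effect), compound 1 `Cn1c(-c2ccc(NC(=O)CSc3nc4ccccc4o3)cc2)nc(-c2ccccc2)c1-c1ccccc1` gives 56%, compound 2 `Cn1c(-c2ccc(NC(=O)CSc3nc4ccccc4s3)cc2)nc(-c2ccccc2)c1-c1ccccc1` gives 50.3%, and compound 3 `Cn1nnnc1SCC(=O)Nc1ccc(-c2nc(-c3ccccc3)c(-c3ccccc3)n2C)cc1` gives 63.7%, the highest of the three numbers; the step of a number 7.7 percentage points higher from compound 1 to compound 3 (within the scatter) is within the scatter, whereas the step of a number 13.4 percentage points higher from compound 2 to compound 3 (beyond the scatter) lies beyond it. Compound 4 `Cc1nnc(SCC(=O)Nc2ccc(-c3nc(-c4ccccc4)c(-c4ccccc4)n3C)cc2)s1` carries the change (5-methyl-1,3,4-thiadiazol-2-yl in place of 1-methyl-1H-tetrazol-5-yl on a sulfur). All three measured steps alter the ring on that sulfur, with sizes of a number 5.7 percentage points lower from compound 1 to compound 2 (within the scatter), a number 7.7 percentage points higher from compound 1 to compound 3 (within the scatter) and a number 13.4 percentage points higher from compound 2 to compound 3 (beyond the scatter), so only a small shift is expected, possibly none beyond the scatter. The estimate for compound 4 in this assay is 56% (range 43% to 68%), which is expected to mean a step of a number 7.7 percentage points lower from compound 3 to compound 4 (within the scatter).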

Compound 4, a percentage reported as activity, at one concentration (the size of the read-out at that concentration, not a potency): 74.9%
Beside the measured number, compound 4's estimate is 18.9 percentage points below it; the measured number lies above the stated range.
By their numbers in this assay, from the lowest: compounds 2, 1 and 3 (each within the scatter of the next, the first and the last beyond it); then compound 4.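

In this assay, going by these compounds alone, the ring on this sulfur can move the number more than the earlier compounds suggested: 5-methyl-1,3,4-thiadiazol-2-yl stands clear of the other three rings, with a number 11.2 percentage points higher from compound 3 to compound 4 (beyond the scatter), a number 18.9 percentage points higher from compound 1 to compound 4 (beyond the scatter) and a number 24.6 percentage points higher from compound 2 to compound 4 (beyond the scatter). Compound 3 and compound 4 carry rings with the same count of heavy atoms, so that count alone does not set the number. Nothing measured here explains why this ring gives the highest value. Still open, from the compounds shown here alone, is whether the methyl on the ring matters, and whether an ethyl group or an amine in its place would keep, raise or lower the number.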